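The compounds below may be only part of what the source reports. "The series", "measured", "known", "first", "only" and "open" are said of these compounds alone.

Working notes on the series. The shared core is seen in compound 1 `C#CCN(CC)Cc1cn(-c2cc(NC(=S)NCC)ncn2)cn1`. In an assay on isolated protein for inhibition of Amine oxidase [flavin-containing] A (Homo sapiens), read by fluorescence and Amplex Red, with a stated time of 15 min (on this read-out higher numbers stand for weaker inhibition and lower numbers for stronger inhibition), compound 1 gives only a limit, > 50000 nM. Compound 2 `C#CCN(CC#N)Cc1cn(-c2cc(NC(=S)NCC)ncn2)cn1` carries cyano in place of methyl on a saturated chain carbon bound to an amine nitrogen, and the step from compound 1 to compound 2 is a step that the two limits leave unreadable from compound 1 to compound 2. In this assay compound 2 also gives only a limit, > 50000 nM. Every value shown so far sits at this limit (the limit of > 50000 nM in this assay, at which 2 of the 2 values shown sit), so compound 2 cannot be placed above or below any other compound on the numbers. Compound 3 `C#CCN1CCN(Cc2cn(-c3cc(NC(=S)NCC)ncn3)cn2)CC1` differs from compound 2 by a group of 9 heavy atoms (7 carbon, 2 nitrogen; one six-membered non-aromatic ring with 2 hetero atoms) in place of a group of 7 heavy atoms (5 carbon, 2 nitrogen; no ring), on a saturated chain carbon bound to an aromatic carbon. Among the measured compounds shown here, the one measured step bears on it only loosely, since it alters the same chain substituent and its size is not readable from two limits. For the measured compounds named here, no measured step therefore supplies a direction or a size for this change, and the working expectation is that compound 3 again returns a limit rather than a number. The estimate for compound 3 in this assay is 60000 nM, with a range from 15000 nM to 250000 nM, and the expected step from compound 2 to compound 3 is a step that the limit leaves unreadable from compound 2 to compound 3.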

Compound 3, half-maximal inhibitory concentration: > 50000 nM
Compound 3 ended at the assay's limit; the forecaster's own chance of this, stated with the estimate: 80%; the middle value lies beyond the limit too.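

In this assay, among the compounds shown here, compound 3 gives > 50000 nM, which is a limit, so no step among compound 1, compound 2 and compound 3 can be read: the limit of > 50000 nM in this assay, at which 3 of the 3 values shown sit. The compounds shown leave open whether any substituent on the saturated chain carbon bound to an aromatic carbon would give a number rather than a limit.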